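A second chloro on compound 1

The compounds below may be only part of what the source reports. "The series", "measured", "known", "first", "only" and "open" are said of these compounds alone.

In a functional assay on PC-3 cells (Homo sapiens) for antiproliferative activity, read by MTT assay, with a stated time of 48 h (on this read-out higher numbers stand for weaker inhibition and lower numbers for stronger inhibition), compound 1 `O=C(/C=C/c1ccc(/C=C/C(=O)c2cccc(Cl)c2)o1)NO` gives 9600 nM and compound 2 `O=C(/C=C/c1ccc(/C=C/C(=O)c2ccccc2)o1)NO` gives 13300 nM as its reading. Only these two numbers are in hand, and they lie within the scatter of each other, so neither can be ranked above the other.

Compound 3 `O=C(/C=C/c1ccc(/C=C/C(=O)c2cc(Cl)ccc2Cl)o1)NO` differs from compound 1 by chloro in place of hydrogen on an aromatic carbon in one place: chloro in place of hydrogen on an aromatic carbon, ortho to a large group and para to a chloro group.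

For the measured compounds named here, one measured step bears on this change. The step of a 1.4-fold higher number from compound 1 to compound 2 (0.14 log units; within the scatter) swaps a chloro for hydrogen and stays within the scatter. Going by the values given here, it runs the opposite way and concerns a different place, and no measured compound yet carries two chloro groups, so the guide is a loose one. A further chloro is therefore expected to make no difference beyond the scatter in this assay and at most a slight drop. The estimate amounts to a 1.1-fold lower number from compound 1 to compound 3 (0.05 log units; within the scatter) and no real shift is expected. Compound 3 is expected at 8500 nM within an estimated range of 4000 nM to 18000 nM on this reading.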

Compound 3, half-maximal inhibitory concentration: 24700 nM
Estimate against measurement, compound 3: 2.9-fold (0.46 log units) below; the measured number lies above the stated range.
By their numbers in this assay, from the lowest: compounds 1, 2 and 3 (each within the scatter of the next, the first and the last beyond it).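

In this assay, the added chloro, on an aromatic carbon ortho to a large group and para to a chloro group, brings a 2.6-fold higher number from compound 1 to compound 3 (0.41 log units; beyond the scatter). This is the only step shown so far that lies beyond the scatter: the chloro removed between compounds 1 and 2 sat at a different place and left two readings that could not be told apart. On this read-out a higher number stands for weaker inhibition, so adding a chloro at this position gives a modest loss of antiproliferative activity, and nothing measured here tells why the number rises.

The compounds shown leave open whether a fluoro, a methyl or an amine at this position would raise the number as the chloro does, or whether the rise belongs to chloro alone. They also leave open whether a chloro here would have the same effect without the other chloro on the ring, as compound 3 carries both.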